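The source may report more compounds than this note shows. Statements on the series, on what has been measured and on what is new or still open speak of the compounds shown alone.

In a functional assay on DU-145 cells (Homo sapiens) for inhibition, read by trypan blue exclusion, with a stated time of 96 h (a higher number here means a weaker inhibitor of growth, a lower number a stronger inhibitor of growth), the measured compounds are:

- Compound 1 `O=C(O)c1ccc(C(=O)/C(=C\c2ccc(O)c([N+](=O)[O-])c2)SCc2ccc(Br)cc2)cc1`: 50000 nM
- Compound 2 `O=C(O)c1ccc(C(=O)/C(=C\c2ccc(Cl)c([N+](=O)[O-])c2)SCc2ccc(Br)cc2)cc1`: 500 nM

Of these two, compound 2 has the lower number, 500 nM, which makes it the stronger inhibitor of growth. Compound 3 `O=C(O)c1ccc(C(=O)/C(=C\c2ccc(O)c(Br)c2)SCc2ccc(Br)cc2)cc1` has not yet been measured. It differs from compound 2 in one place: 3-bromo-4-hydroxyphenyl in place of 4-chloro-3-nitrophenyl on a double-bonded chain carbon bound to a double-bonded chain carbon. That is, 3-bromo-4-hydroxyphenyl stands in place of 4-chloro-3-nitrophenyl.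

Among the measured compounds shown here, only one measured step bears on this change. Chloro in place of hydroxy on an aromatic carbon gave a 100-fold lower number from compound 1 to compound 2 (2.00 log units; beyond the scatter), a large step beyond the scatter. Compound 3 carries a hydroxy, as compound 1 does, so a higher number than that of compound 2 is expected in this assay. For the measured compounds named here, no measured step covers bromo in place of nitro, so the size remains uncertain. The expected change is a 20-fold higher number from compound 2 to compound 3 (1.30 log units; beyond the scatter). For compound 3, the estimated value is 10000 nM, with an expected range of 2000 nM to 50000 nM.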

Compound 3, concentration for 50% growth inhibition: 25000 nM
Beside the measured number, compound 3's estimate is 2.5-fold (0.40 log units) below it; the measured number falls inside the stated range.
By their numbers in this assay, from the lowest: compound 2; then compounds 3 and 1 (each within the scatter of the next).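

In this assay, the full exchange of 4-chloro-3-nitrophenyl for 3-bromo-4-hydroxyphenyl gives a 50-fold higher number from compound 2 to compound 3 (1.70 log units; beyond the scatter) and so loses most of the strength seen with compound 2. Bromo in place of nitro on an aromatic carbon, with the hydroxy kept, gives a 2.0-fold lower number from compound 1 to compound 3 (0.30 log units; within the scatter) and so leaves the two hydroxy-bearing compounds indistinguishable in this assay, which shows that this exchange does not restore what the change from hydroxy to chloro brought. Nothing measured on these compounds explains either step.

Still open, going by these compounds, is whether chloro in place of hydroxy would bring as large a step with bromo in place of nitro. On these data alone, it is also open whether an amine or a methoxy on that aromatic carbon would give a number closer to that of the hydroxy compounds or to that of compound 2.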